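The source may report more compounds than this note shows. Statements on the series, on what has been measured and on what is new or still open speak of the compounds shown alone.

- Compound 1 `C#CCN(Cc1ccc2nc(C)nc(O)c2c1)c1cccc(CO)c1`: 48000 nM
- Compound 2 `C#CCN(Cc1ccc2nc(C)nc(O)c2c1)c1cccc(C(C)O)c1`: > 49000 nM, a limit
- Compound 3 `C#CCN(Cc1ccc2nc(C)nc(O)c2c1)c1cccc(C#C)c1`: not yet measured

In a functional assay on L1210 cells (Mus musculus) for inhibition (a higher number here means a weaker inhibitor, a lower number a stronger inhibitor), compound 2 stands only at a limit, > 49000 nM. That limit is where the series' data end: the limit of > 49000 nM in this assay, at which 1 of the 2 values shown sits. The next structure, compound 3, puts ethynyl in place of 1-hydroxyethyl on an aromatic carbon. Among the compounds with values here, the one measured step bearing on this group is an at least 1.0-fold higher number from compound 1 to compound 2 (0.00 log units; that floor lies within the scatter). It gives no size of change beyond the scatter, so no step beyond the scatter is expected in this assay. Compound 3 is estimated at 35000 nM, with an expected range from 10000 nM to 62000 nM. This estimate means an expected at least 1.4-fold lower number from compound 2 to compound 3 (0.14 log units; that floor lies within the scatter).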

Compound 3, half-maximal inhibitory concentration: > 2400 nM
Compound 3 was reported as a limit; the forecaster's own chance of this, stated with the estimate: 35%; the middle value does not contradict the limit.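

In this assay compound 3 gives only a limit, > 2400 nM, so the steps to it from compound 1 and compound 2 cannot be read. The compounds shown leave open how ethynyl compares with hydroxymethyl or 1-hydroxyethyl for inhibition.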